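The source may report more compounds than this note shows. Statements on the series, on what has been measured and on what is new or still open speak of the compounds shown alone.

The series shares the core of compound 1 `COc1cc2c(=O)c(S(=O)(=O)CCc3ccc(Cl)cc3)cn(Cc3ccccc3)c2cc1OC`, which in an ADME assay on Huh-7 cells (Homo sapiens) for cytotoxicity (a lower number here means a stronger inhibitor of growth, a higher number a weaker inhibitor of growth), was recorded as "not active" (no number reported), with no number given. Compound 3 `COc1cc2c(=O)c(C(=O)OCc3ccc(Cl)cc3)cn(Cc3ccccc3)c2cc1OC` gives 28300 nM in this assay. Compound 2 `COc1cc2c(=O)c(C(=O)OCc3ccccc3C)cn(Cc3ccc(C(F)(F)F)cc3F)c2cc1OC` gives 31000 nM in this assay, the higher of the two numbers reported, yet compound 3 sits within the scatter of it, so the two cannot be told apart. The unmeasured compound 4 `COc1cc2c(=O)c(C(=O)OCc3ccc(C)cc3)cn(Cc3ccc(C(F)(F)F)cc3F)c2cc1OC` differs from compound 2 in a single place: 4-methylphenyl in place of 2-methylphenyl on a saturated chain carbon bound to an oxygen next to a carbonyl group. Going by the values given here, no step between measured compounds of this kind is available, and the two measured numbers lie within the scatter of each other, so nothing in the data points in either direction. Compound 4 is expected to move by a 1.0-fold lower number from compound 2 to compound 4 (0.01 log units; within the scatter), nothing beyond the scatter. Compound 4 is therefore estimated at 30000 nM in this assay, with a range from 12000 nM to 75000 nM.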

Compound 4, concentration for 50% growth inhibition: 20000 nM
Compound 4: middle estimate off by 1.5-fold (0.18 log units), on the high side; measured number inside the range.
By their numbers in this assay, from the lowest: compounds 4, 3 and 2 (each within the scatter of the next).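

In this assay, the change from 2-methylphenyl to 4-methylphenyl on a saturated chain carbon bound to an oxygen next to a carbonyl group gives a 1.6-fold lower number from compound 2 to compound 4 (0.19 log units; within the scatter). Going by these compounds alone, this is the first step read between two measured compounds that differ in one place, and it shows that this exchange of two groups with the same atoms does not separate the compounds in this assay. No supporting evidence bears on this result.

The compounds shown leave open how an amine or a carboxylic acid in place of the methyl group on the 4-methylphenyl would read in this assay. Also open, going by these compounds, is whether a longer chain in place of that methyl group would stay within the scatter of compound 4.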